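Compound 3: (pyrrolidin-1-yl)carbonyl on the shared core

A few compounds are considered here, and "the series" means these few. Any claim that something is new, unique, unknown or untested is made for them only; others in the source may bear on it.

In a functional assay on HL-60 cells (Homo sapiens) for antiproliferative activity, read by MTT assay, with a stated time of 48 h (on this read-out higher numbers stand for weaker inhibition and lower numbers for stronger inhibition), compound 2 `CSC(=S)OC/C1=C/C[C@](C)(CCC=C(C)C)/C=C/[C@@H](OC(=O)C=C(C)C)[C@](C)(O)/C=C/C1=O` gives 180 nM and compound 1 `CCN(CC)C/C1=C/C[C@](C)(CCC=C(C)C)/C=C/[C@@H](OC(=O)C=C(C)C)[C@](C)(O)/C=C/C1=O` gives 140 nM. These two numbers lie within the scatter of each other, so compound 2 holds no separate place in this pair. Compound 3 `CC(C)=CCC[C@]1(C)/C=C/[C@@H](OC(=O)C=C(C)C)[C@](C)(O)/C=C/C(=O)/C(C(=O)N2CCCC2)=C\C1` has not yet been measured. Its difference from compound 2 is a group of 7 heavy atoms (5 carbon, 1 nitrogen, 1 oxygen; one five-membered non-aromatic ring with 1 hetero atom) in place of a group of 6 heavy atoms (3 carbon, 1 oxygen, 2 sulfur; no ring), on a double-bonded ring carbon: (pyrrolidin-1-yl)carbonyl enters on a double-bonded ring carbon of the shared core, replacing the sulfur-bearing group of compound 2.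

Among the measured compounds shown here, the only measured step that bears on this is a 1.3-fold higher number from compound 1 to compound 2 (0.11 log units; within the scatter), a replacement on a saturated chain carbon bound to a double-bonded ring carbon. That step stayed within the scatter. Neither compound 1 nor compound 2 carries a (pyrrolidin-1-yl)carbonyl group, however, so the evidence is thin and the range must stay wide. No step beyond the scatter is expected in this assay. The expected change is a 1.4-fold higher number from compound 2 to compound 3 (0.14 log units; within the scatter). For compound 3 the estimated value is 250 nM, with an expected range of 70 nM to 900 nM.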

Compound 3, half-maximal inhibitory concentration: 12300 nM
For compound 3 the middle estimate is 49-fold (1.69 log units) below the measured one, and the stated range ends below it.
By their numbers in this assay, from the lowest: compounds 1 and 2 (each within the scatter of the next); then compound 3.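

In this assay the double-bonded ring carbon turns out to be sensitive to the group it carries: the series now shows a 68-fold higher number from compound 2 to compound 3 (1.83 log units; beyond the scatter) and an 88-fold higher number from compound 1 to compound 3 (1.94 log units; beyond the scatter) and both steps are large, whereas the earlier replacement, a 1.3-fold higher number from compound 1 to compound 2 (0.11 log units; within the scatter) gave no sign of this. Among the compounds shown here, in compounds 1 and 2 the group on this ring carbon begins with a saturated chain carbon, and two quite different groups built on that start, (diethylamino)methyl and the sulfur-bearing group, stay within the scatter of each other, while in compound 3 the group begins with a carbonyl and only this compound stands apart. Nothing at hand gives a reason for the rise.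

The compounds shown leave open whether the large rise goes with the carbonyl or with the pyrrolidine ring, since compound 3 changes both at once. A (pyrrolidin-1-yl)methyl group and a (diethylamino)carbonyl group on the same ring carbon would separate the two, each differing from a compound shown in that one feature.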